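The source may hold more compounds than are shown below. What is called first, only, known or untested is meant among the compounds shown, and "the series" means these compounds.

Of the compounds shown here, two have so far been measured in an assay on microsomes from liver for inhibition of 3-hydroxy-3-methylglutaryl-coenzyme A reductase (Rattus norvegicus), read by scintillation counting, with stated times of 0.5 h and 0.75 h; on this read-out lower numbers stand for stronger inhibition and higher numbers for weaker inhibition. Compound 1 `O=C(O)C[C@H](O)C[C@H](O)CCn1c(-c2ccc(F)cc2)nc(C(=O)NCc2ccc(F)cc2)c1C1CC1` gives 3.4 nM in this assay. Compound 2 `Cc1ccccc1CNC(=O)c1nc(-c2ccc(F)cc2)n(CC[C@@H](O)C[C@@H](O)CC(=O)O)c1C1CC1` carries a 2-methylphenyl in place of the 4-fluorophenyl on a saturated chain carbon bound to an amide-type nitrogen, and in this assay compound 2 gives 4.9 nM. That exchange produced a 1.4-fold higher number from compound 1 to compound 2 (0.16 log units; within the scatter). Compound 2 thus holds the higher of the two numbers, but its nearest neighbour, compound 1, sits within the scatter, so the two cannot be told apart on these data.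

Compound 3 `O=C(O)C[C@H](O)C[C@H](O)CCn1c(-c2ccc(F)cc2)nc(C(=O)NCc2cccc(F)c2)c1C1CC1` has not yet been measured. It differs from compound 2 by 3-fluorophenyl in place of 2-methylphenyl on a saturated chain carbon bound to an amide-type nitrogen. Going by the values given here, only one measured step bears on this change: a 1.4-fold higher number from compound 1 to compound 2 (0.16 log units; within the scatter) also swapped the group at this same place and stayed within the scatter. The new group is expected to behave much like the two already tried, so no step beyond the scatter is expected, the estimated step being a 1.2-fold lower number from compound 2 to compound 3 (0.09 log units; within the scatter). Compound 3 is therefore estimated at 4 nM, with a likely range from 1.8 nM to 9 nM.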

Compound 3, half-maximal inhibitory concentration in the 3-hydroxy-3-methylglutaryl-coenzyme A reductase assay: 1.2 nM
Compound 3: the middle estimate sits 3.3-fold (0.52 log units) above what was measured, outside the stated range (below it).
By their numbers in the 3-hydroxy-3-methylglutaryl-coenzyme A reductase assay, from the lowest: compound 3; then compounds 1 and 2 (each within the scatter of the next).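

Going by these compounds alone, in the 3-hydroxy-3-methylglutaryl-coenzyme A reductase assay, the 3-fluorophenyl on a saturated chain carbon bound to an amide-type nitrogen gives the first steps at this place that lie beyond the scatter (a 4.1-fold lower number from compound 2 to compound 3 (0.61 log units; beyond the scatter)) and (a 2.8-fold lower number from compound 1 to compound 3 (0.45 log units; beyond the scatter)), so compound 3 has the lowest number of the three and this place does respond to the group it carries. Compound 1 and compound 3 differ only in 4-fluorophenyl against 3-fluorophenyl, so among these compounds the place of the fluorine on the ring changes the result, even though the atoms counted in the group stay the same. In a physicochemical assay for lipophilicity, using the shake flask method, at pH 7.4 (a higher number here means a more lipophilic compound, a lower number a more polar compound), compound 2 gives 0.44 and compound 3 gives 0.51, which is (a number 0.07 log units higher from compound 2 to compound 3 (within the scatter)), so the lower number in the 3-hydroxy-3-methylglutaryl-coenzyme A reductase assay comes with no difference beyond the scatter on this second measure.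

Nothing available here says why the 3-fluorophenyl gives the lower number. Also open, on these data alone, is whether the result is tied to fluorine at that ring place, which 3-chlorophenyl or 3-methylphenyl could test, and whether a longer chain between the amide-type nitrogen and the ring would keep it.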